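This account rests on a few compounds, and the source may have more. Where it says the series, first, only, none or still open, it means among the compounds named here.

Of the compounds shown here, two with a shared core have been tested in a functional assay, with a stated time of 6 min; on this read-out lower numbers stand for stronger inhibition and higher numbers for weaker inhibition. Compound 1, with the structure `S=c1[nH]nc(-c2ccc3c(c2)OCCO3)o1`, gives 10600 nM. Compound 2, with the structure `Fc1ccc(NCn2nc(-c3ccc4c(c3)OCCO4)oc2=S)cc1`, gives 6480 nM. The gap between these two numbers lies within the usual scatter of repeated measurements, so on the numbers shown compound 2 cannot be set apart from compound 1: the two readings are, for practical purposes, the same.

Compound 3, with the structure `S=c1oc(-c2ccc3c(c2)OCCO3)nn1CNc1cc(Cl)ccc1Cl`, has not yet been measured in this assay. Compared with compound 2 it carries one change: 2,5-dichlorophenyl in place of 4-fluorophenyl on an amine nitrogen. Within the data shown here, no step between two measured compounds is available to show how such a change has played out before, so the expectation rests on the two readings alone. The two halogen-bearing aryl groups are of similar size, and the rest of the structure is untouched, so the step from compound 2 to compound 3 is expected to be small, most likely no larger than the scatter itself, as a 1.1-fold lower number from compound 2 to compound 3 (0.03 log units; within the scatter). Compound 3 is therefore expected to give about 6000 nM, within a range from 2500 nM to 15000 nM.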

Compound 3, half-maximal inhibitory concentration: 5420 nM
The estimate for compound 3 lay 1.1-fold (0.04 log units) above the measured number; measured number inside the range.
By their numbers in this assay, from the lowest: compounds 3, 2 and 1 (each within the scatter of the next).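

In this assay, 2,5-dichlorophenyl in place of 4-fluorophenyl on the amine nitrogen gives a 1.2-fold lower number from compound 2 to compound 3 (0.08 log units; within the scatter). Among these compounds, this is the first step that can be read at this position, and it shows that this exchange of one halogen-bearing aryl group for another leaves the reading indistinguishable from that of compound 2. The halogen, the number of halogens and their places on the ring all change together, so this one step cannot separate their contributions or show whether they offset one another, and no measurement on hand explains why the two readings stay so close.

On these data alone, it remains open whether a group of another kind on this amine nitrogen, such as a ring bearing a carboxylic acid or a cyclohexyl group in place of the aryl ring, would give a reading clearly set apart from those of compound 2 and compound 3. As far as these compounds go, it is also open whether a longer chain in place of the saturated chain carbon on this nitrogen would change the reading beyond the usual scatter.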